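The source may report more compounds than this note shows. Statements on the series, on what has been measured and on what is new or still open speak of the compounds shown alone.

Measured so far, all in a functional assay on MCF7 cells (Homo sapiens) for antiproliferative activity, read by MTT assay, with a stated time of 48 h (a higher number here means a weaker inhibitor, a lower number a stronger inhibitor), as the read-out
compound 1 `C#CCOc1ccc(/C=C/C(C)=O)cc1OC` at 65400 nM
compound 2 `COc1cc(/C=C/C(C)=O)ccc1OCc1cn(-c2c(Cl)cccc2Cl)nn1` at 26600 nM
compound 3 `COc1cc(/C=C/C(C)=O)ccc1OCc1cn(-c2ccc(-c3ccccc3)cc2)nn1` at 65400 nM

Compound 2 holds the lowest number of the three, and its distance to compound 1 and to compound 3 lies beyond the scatter in each case. Compound 1 and compound 3 show the same number. Going by the values given here, no two measured compounds are available as a pair differing in one place, so no measured step bears directly on the next change.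

Compound 4 `COc1cc(/C=C/C(C)=O)ccc1OCc1cn(-c2cc(F)cc(Br)c2)nn1` is still to be measured. It carries 3-bromo-5-fluorophenyl in place of 2,6-dichlorophenyl on an aromatic nitrogen and otherwise keeps the structure of compound 2.

Among the compounds with values here, the only guide is the narrow spread of the values, with compound 2 at 26600 nM and compound 3 at 65400 nM at its two ends. Since compound 2 already sits at the low end, a small rise is expected rather than a fall, and no step beyond the scatter is expected. The estimate means a 1.3-fold higher number from compound 2 to compound 4 (0.12 log units; within the scatter) as the expected step, a small upward move within the scatter. Compound 4 is estimated at 35000 nM (expected range 15000 nM to 75000 nM)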

Compound 4, half-maximal inhibitory concentration: 65500 nM
For compound 4 the middle estimate is 1.9-fold (0.27 log units) below the measured one, and the stated range covers the measured number.
By their numbers in this assay, from the lowest: compound 2; then compounds 1, 3 and 4 (each within the scatter of the next).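

In this assay, going by these compounds alone, the replacement of 2,6-dichlorophenyl by 3-bromo-5-fluorophenyl on an aromatic nitrogen of the five-membered ring gives the first readable step, a 2.5-fold higher number from compound 2 to compound 4 (0.39 log units; beyond the scatter), so the read-out at this position responds to the change even though both groups count 8 heavy atoms, with no hydrogen-bond donors or acceptors. The step is modest, and it leaves compound 4 at 65500 nM within the scatter of compound 3 at 65400 nM, so of these compounds only compound 2, at 26600 nM, stands apart from the rest. No measured information on the two groups accounts for the step.

As far as these compounds go, the step exchanges the halogens and their places on the phenyl ring together, so it remains open whether the lower number of compound 2 goes with the two chlorine atoms or with where they sit. Also open, from the compounds shown here alone, is how an unsubstituted phenyl, or a phenyl carrying an amine or a carboxylic acid, would read on the same nitrogen in this assay.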